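Cyanoaziridine ureas: small-group change at the amide nitrogen

A few compounds are considered here, and "the series" means these few. Any claim that something is new, unique, unknown or untested is made for them only; others in the source may bear on it.

Of the compounds shown here, two have numbers so far. Compound 1 `N#CC1CN1C(=O)Nc1ccc(Cl)c(Cl)c1` carries a dichlorophenyl urea; compound 2 `CNC(=O)N1CC1C#N` keeps the shared cyanoaziridine core with only a methylamino group on the urea. In a functional assay on A-375 cells (Homo sapiens) for inhibition (on this read-out higher numbers stand for weaker inhibition and lower numbers for stronger inhibition), compound 1 gives 5900 nM, and in this assay compound 2 gives 17000 nM. Compound 2 thus stands at the highest of the two numbers, and the gap to compound 1 lies beyond the scatter, so compound 2 is the weaker of the pair.

Compound 3 `CCNC(=O)N1CC1C#N` remains to be measured in this assay. It differs from compound 2 by methyl in place of hydrogen on a saturated chain carbon bound to an amide-type nitrogen. For the measured compounds named here, no step between measured compounds covers this kind of change, so the only footing is that the two known numbers differ in a different and much larger part of the structure. A change of one carbon on the chain is expected to move the number little, if at all, with any movement more likely toward a lower number than a higher one.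

For compound 3 the expected value in this assay is 13000 nM, within a range of 5000 nM to 32000 nM. This estimate means a step from compound 2 to compound 3 of a 1.3-fold lower number from compound 2 to compound 3 (0.12 log units; within the scatter), not beyond the scatter.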

Compound 3, half-maximal inhibitory concentration: 36000 nM
Compound 3: middle estimate off by 2.8-fold (0.44 log units), on the low side; measured number outside the range, above it.
By their numbers in this assay, from the lowest: compound 1; then compound 2; then compound 3.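

In this assay, methyl in place of hydrogen on a saturated chain carbon bound to an amide-type nitrogen gives a 2.1-fold higher number from compound 2 to compound 3 (0.33 log units; beyond the scatter), so this position responds to a single added carbon, and the response runs toward weaker inhibition. For the compounds shown here, this is the first step that isolates one change in one place; the earlier pair differs in a much larger part of the structure and could not give a reading for the small chain alone. Nothing at hand bears on the reason for this modest loss.

A single step from methylamino to ethylamino does not show whether the move continues with chain length, so a propyl or longer chain on the same nitrogen would be needed to tell a steady trend from a one-off change. On these data alone, it also remains open whether a chain ending in an amine or a carboxylic acid, or a plain phenyl group without chlorine, would connect these small ureas to the dichlorophenyl urea of compound 1 through steps of one change each.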